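The source may report more compounds than this note shows. Statements on the series, on what has been measured and on what is new or still open speak of the compounds shown alone.

Working notes on the series. Compound 1 `O=[N+]([O-])c1cn2c(n1)OC(COc1ccc(-c3ccc(F)cc3)cc1)C2` and compound 2 `O=[N+]([O-])c1cn2c(n1)OC(COc1ccc(-c3ccc(C(F)(F)F)cc3)cc1)C2` share one core; compound 3 `CC1(COc2ccc(-c3ccc(F)cc3)cn2)Cn2cc([N+](=O)[O-])nc2O1` and compound 4 `CC1(COc2ccc(-c3ccc(C(F)(F)F)cc3)cn2)Cn2cc([N+](=O)[O-])nc2O1` share another, and the difference between the two cores is not broken down here. In an ADME assay on MRC5 cells (Homo sapiens) for cytotoxicity, read by fluorescence, with a stated time of 72 h (on this read-out higher numbers stand for weaker inhibition and lower numbers for stronger inhibition), compound 1 gives only a limit, > 64000 nM. In this assay compound 2 likewise gives only a limit, > 64000 nM. In this assay compound 3 gives only a limit, > 64000 nM. The change trifluoromethyl in place of fluoro on an aromatic carbon thus gives a step that the two limits leave unreadable from compound 1 to compound 2, a step that cannot be read because of the limit of > 64000 nM in this assay, at which 3 of the 3 values shown sit. The same change, (trifluoromethyl in place of fluoro on an aromatic carbon), is made from compound 3 to compound 4. For compound 4 the expected step is a number no higher from compound 3 to compound 4 (the limit leaves the size open), resting on compound 1 and compound 2 both sitting at the limit in this assay and on (the limit of > 64000 nM in this assay, at which 3 of the 3 values shown sit). The estimate for compound 4 in this assay is therefore 64000 nM, with an expected range from 30000 nM to 100000 nM.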

Compound 4, half-maximal inhibitory concentration: > 64000 nM
Compound 4: no number, only a limit; the forecaster's own chance of this, stated with the estimate: 85%; the middle value lies on the limit itself.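

No step can be read from compound 3 to compound 4 in this assay, because both values are limits: the limit of > 64000 nM in this assay, at which 4 of the 4 values shown sit.

The compounds shown leave open what effect, if any, trifluoromethyl in place of fluoro has on either core.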